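The source may hold more compounds than are shown below. What is called first, only, known or untested is meant among the compounds shown, and "the series" means these compounds.

Measured so far in a functional assay on the whole organism for inhibition, with Rattus norvegicus as the target, at a dose of 25 mg/kg by the intraperitoneal route; on this read-out lower numbers stand for less inhibition and higher numbers for more inhibition at the one dose given (going by the name of the read-out):
- compound 1 `CN(C)c1ncnc2c1ncn2Cc1ccc(F)cc1`: 21%
- compound 2 `Cc1cccc(Cn2cnc3c(N(C)C)ncnc32)c1`: 12%

Compound 2 carries the lowest of the two numbers, though the gap to compound 1 is within the scatter, so the two read as equivalent. Compound 3 `COc1cccc(Cn2cnc3c(N(C)C)ncnc32)c1` is the next compound for this assay; it differs from compound 2 by methoxy in place of methyl on an aromatic carbon. For the measured compounds named here, no step between measured compounds is available to size this change, so no step beyond the scatter is expected in this assay. For compound 3 the estimate is 14% with a range from 2% to 28%, a step of a number 2 percentage points higher from compound 2 to compound 3 (within the scatter) that is expected to stay within the scatter.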

Compound 3, a percentage reported as inhibition, in the whole organism at one dose (the size of the read-out at that dose, not a potency): 48%
Compound 3: middle estimate off by 34 percentage points, on the low side; measured number above the stated range.
By their numbers in this assay, from the lowest: compounds 2 and 1 (each within the scatter of the next); then compound 3.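

In this assay, for the compounds shown here, the aromatic carbon meta to a large group proves sensitive to its substituent: methoxy in place of methyl gives a number 36 percentage points higher from compound 2 to compound 3 (beyond the scatter), the only step so far that can be sized on this position. The change adds one oxygen and one hydrogen-bond acceptor, and this single pair cannot separate the two. No measurement at hand bears on the cause of the step.

Still open, from the compounds shown here alone, is whether a hydroxyl, an ethoxy or an amine on the same carbon would hold this read-out. Also open, going by these compounds, is how methoxy behaves elsewhere on the ring.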